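Shortening a Bromoalkyl Chain on an Inactive Scaffold

This account rests on a few compounds, and the source may have more. Where it says the series, first, only, none or still open, it means among the compounds named here.

Of the compounds shown here, three of the same family have been tested in a functional assay on NCI-H1299 cells (Homo sapiens) for cytotoxicity, read by fluorescence and resazurin assay, with a stated time of 48 h; a higher number here means a weaker inhibitor, a lower number a stronger inhibitor. Compound 1, `COc1ccc(/C=C/c2cc(/C=C/c3ccc(OC)c(OC)c3)nc(OCCCCCCBr)n2)cc1OC`, reaches only the limit of the measurement, > 20000 nM. Compound 2, `COc1cc(/C=C/c2cc(/C=C/c3cc(OC)c(OC)c(OC)c3)nc(OCCCCCCBr)n2)cc(OC)c1OC`, likewise gives a limit rather than a number, > 20000 nM. Compound 3, `BrCCCCOc1nc(/C=C/c2ccccc2)cc(/C=C/c2ccccc2)n1`, also stops at the limit, > 20000 nM. Compound 2 therefore stands nowhere in particular: its value is only a limit, and so are the two others, so no order among them can be drawn; the limit of > 20000 nM in this assay, at which 3 of the 3 values shown sit, is the whole of the evidence.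

The next compound, compound 4, `COc1cc(/C=C/c2cc(/C=C/c3cc(OC)c(OC)c(OC)c3)nc(OCCCCBr)n2)cc(OC)c1OC`, keeps everything of compound 2 except the length of its chain. bromo in place of 2-bromoethyl on a saturated chain carbon, four bonds along the chain from an oxygen on an aromatic ring Compound 3, whose structure also holds a 4-bromobutyl chain on the shared core, sits at the limit too.

Among the measured compounds shown here, no step between measured compounds is available to say how chain length matters here, since every measured value is a limit. In this assay the expected step is a step that the limit leaves unreadable from compound 2 to compound 4, nothing beyond the scatter. Compound 4 is expected to give about 30000 nM, within 10000 nM to 100000 nM, and most likely to be reported once more only as a limit rather than a number.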

Compound 4, half-maximal inhibitory concentration: > 20000 nM
Compound 4 ended at the assay's limit (the forecaster's own chance of this, stated with the estimate: 85%); the middle value is on the limit's open side.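

In this assay compound 4 gives > 20000 nM, which is a limit and not a number. Compound 2 also sits at a limit, so no step can be read between compound 2 and compound 4. The compounds shown leave open whether the length of the bromoalkyl chain makes any difference to cytotoxicity on this core.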